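This account rests on a few compounds, and the source may have more. Where it says the series, first, only, none or still open, it means among the compounds named here.

Of the compounds shown here, two have been measured so far in an assay on isolated protein for inhibition of protein kinase C delta type (Homo sapiens), read by TR-FRET, with a stated time of 2 h; on this read-out higher numbers stand for weaker inhibition and lower numbers for stronger inhibition. Compound 1 `CC1(C)C[C@H](Nc2cc(NCc3cnccc3C(F)(F)F)ncc2C#N)CC[C@@H]1O` gives 500 nM in this assay. Compound 2 `CC1(C)C[C@H](Nc2nc(NCc3cnccc3C(F)(F)F)ncc2C#N)CC[C@@H]1O` gives 800 nM in this assay, the higher of the two numbers, though its gap to compound 1 lies within the usual scatter, so the two cannot be ranked against each other. Compound 3 `CC1(C)[C@@H](O)C[C@H]1Nc1nc(NCc2cnccc2C(F)(F)F)ncc1C#N` has not yet been measured. It differs from compound 2 in one place: 3-hydroxy-2,2-dimethylcyclobutyl in place of 4-hydroxy-3,3-dimethylcyclohexyl on a nitrogen on an aromatic ring. For the measured compounds named here, no measured pair in this set carries such a change, so there is no step from which its size can be read. With the hydroxyl and both methyl groups kept but the ring made smaller, a modest move toward weaker inhibition in this assay is expected, as a 1.5-fold higher number from compound 2 to compound 3 (0.18 log units; within the scatter), while a result inside the scatter would not be surprising. The expected value for compound 3 in this assay is 1200 nM, with a range from 400 nM to 4000 nM.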

Compound 3, half-maximal inhibitory concentration: 600 nM
For compound 3 the middle estimate is 2.0-fold (0.30 log units) above the measured one; measured number inside the range.
By their numbers in this assay, from the lowest: compounds 1, 3 and 2 (each within the scatter of the next).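

In this assay, for the compounds shown here, the step from 4-hydroxy-3,3-dimethylcyclohexyl to 3-hydroxy-2,2-dimethylcyclobutyl on the nitrogen is a 1.3-fold lower number from compound 2 to compound 3 (0.12 log units; within the scatter) and gives the first direct reading at this position. With the hydroxyl and both methyl groups kept, the four-membered carbon ring and the six-membered one cannot be told apart in this measurement, so this position tolerates this change in ring size. No supporting data bear on why the two rings read alike.

The compounds shown leave open what the hydroxyl and the two methyl groups each contribute, as every ring at this position carries all of them. Also open, from the compounds shown here alone, are the effects of an amine in place of the hydroxyl, of a cyclopentyl ring, and of the same ring change on the core of compound 1.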